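The compounds below may be only part of what the source reports. "The series", "measured", "known", "first", "only" and "open" are said of these compounds alone.

Three salicylanilide-type amides have been measured in a functional assay on HL-60 cells (Homo sapiens) for cytotoxicity, read by luminescence and CellTiter-Glo, with a stated time of 3 days; a lower number here means a stronger inhibitor, a higher number a weaker inhibitor. Compound 1, `O=C(Nc1ccc(OC(F)(F)F)c(Cl)c1)c1ccc(C(F)(F)F)cc1O`, gives 380 nM. Compound 3, `O=C(Nc1cc(C(F)(F)F)cc(C(F)(F)F)c1)c1cc(Cl)c(F)cc1O`, gives 430 nM. Compound 2, `N#Cc1ccc(NC(=O)c2ccc3ccccc3c2O)cc1`, gives 3410 nM, the highest of the three numbers: compound 3 sits closest to it and compound 1 furthest away, both well beyond the scatter of repeated measurements, so compound 2 is the weakest of the three in this assay.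

Compound 4, `N#Cc1ccc(NC(=O)c2ccc3ccccc3c2)cc1`, has not yet been measured. It differs from compound 2 in one place: hydrogen in place of hydroxy on an aromatic carbon. The hydroxy group on the fused ring is shared by all three measured compounds, so none of them shows what happens when it is removed.

In the absence of a measured step of this kind, the expectation for compound 4 rests on compound 2 alone, with 3410 nM as the starting point. The step is expected to go toward a weaker inhibitor, a 2.6-fold higher number from compound 2 to compound 4 (0.42 log units; beyond the scatter), beyond the scatter, with wide uncertainty. Compound 4 is therefore estimated at 9000 nM, within a range of 2500 nM to 35000 nM.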

Compound 4, half-maximal inhibitory concentration: > 10000 nM
Compound 4 gave a limit, no number (the forecaster's own chance of this, stated with the estimate: 20%); middle value at least 1.1-fold (0.04 log units) away from the limit.
By their numbers in this assay, from the lowest: compounds 1 and 3 (each within the scatter of the next); then compound 2. At a limit, above all of these: compound 4.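

In this assay, putting hydrogen in place of hydroxy on this aromatic carbon gives an at least 2.9-fold higher number from compound 2 to compound 4 (0.46 log units; beyond the scatter), which shows that, on the core of compound 2, losing the hydroxy group moves the result toward a weaker inhibitor. Compound 1, compound 2 and compound 3 all carry a hydroxy group, so none of them could show this on its own. The result for compound 4 is a limit and not a number, so the step gives only the smallest size this change can have: the limit of > 10000 nM in this assay, at which 1 of the 4 values shown sits.

The compounds shown leave open whether another group on this aromatic carbon, such as an amine or a methoxy group, could take the place of hydroxy. They also leave open whether removing hydroxy has a similar effect on the cores of compound 1 and compound 3.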